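A benzyl swapped for a methyl ester on a shared core

The source may hold more compounds than are shown below. What is called first, only, known or untested is meant among the compounds shown, and "the series" means these compounds.

Compound 1, `COC(=O)C(C)n1n[n+]([O-])c2cc(C)c(C)cc21`: > 100 ug/mL
Compound 2, `Cc1cc2c(cc1C)[n+]([O-])nn2Cc1ccccc1`: > 100 ug/mL

In a functional assay on HeLa cells (Homo sapiens) for inhibition, read by colorimetric assay, with a stated time of 72 h (on this read-out higher numbers stand for an effect only at larger amounts of compound and lower numbers for an effect already at smaller amounts), compound 1 gives > 100 ug/mL, which is a limit of the assay and not a number. Compound 2 gives > 100 ug/mL in this assay, again a limit rather than a measured number. Both values sit at the same limit (the limit of > 100 ug/mL in this assay, at which 2 of the 2 values shown sit), so compound 2 stands at the ceiling of what the assay reports, with no number that would place it above or below compound 1.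

Compound 3, `COC(=O)Cn1n[n+]([O-])c2cc(C)c(C)cc21`, differs from compound 2 in one place: methoxycarbonyl in place of phenyl on a saturated chain carbon bound to an aromatic nitrogen. Compound 3 thereby shares its core and its methoxycarbonyl group with compound 1, which itself gave only a limit. Among the compounds with values here, no step between measured compounds exists to calibrate this change, and with both measured values at the limit no direction can be read from the data. The expected step that the limit leaves unreadable from compound 2 to compound 3 is therefore none beyond the scatter. Compound 3 is expected to give 150 ug/mL, within 50 ug/mL to 500 ug/mL, most likely reported once more only as a limit.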

Compound 3, concentration for half-maximal effect: > 100 ug/mL
Compound 3 gave a limit, no number (the forecaster's own chance of this, stated with the estimate: 85%); the middle value does not contradict the limit.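

In this assay compound 3 gives > 100 ug/mL, which is a limit of the assay and not a number. The steps to compound 3 from compound 1 and from compound 2 therefore cannot be read: the limit of > 100 ug/mL in this assay, at which 3 of the 3 values shown sit.

The compounds shown leave open whether any group on this saturated chain carbon of the shared core would give a measured number in this assay.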